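The compounds below may be only part of what the source reports. "The series", "measured", "known", "first", "only" and "open" are said of these compounds alone.

Measured so far:
- compound 1 `COc1ccc(N/C=C\C(=O)c2nc(-c3ccc(C(F)(F)F)cc3)n3ccccc23)cc1OC` — a functional assay on B16-F10 cells (Mus musculus) for cytotoxicity, read by MTT assay, with a stated time of 48 h; a lower number here means a stronger inhibitor, a higher number a weaker inhibitor: > 30000 nM
- compound 2 `O=C(/C=C\Nc1cnc2ccccc2c1)c1nc(-c2ccccc2)n2ccccc12` — this assay: 3780 nM
- compound 3 `COc1ccc(N/C=C\C(=O)c2nc(-c3ccc(F)cc3)n3ccccc23)cc1` — this assay: 2560 nM

The value for compound 1 is a limit of this assay, not a number; it sits at the limit of > 30000 nM in this assay, at which 1 of the 3 values shown sits. Compound 2 and compound 3, which carry other aryl groups on the amine nitrogen, give measurable numbers in this assay, and those two numbers lie within the usual scatter of each other.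

Compound 4 `O=C(/C=C\Nc1ccc(Cl)cc1)c1nc(-c2ccc(C(F)(F)F)cc2)n2ccccc12` differs from compound 1 by 4-chlorophenyl in place of 3,4-dimethoxyphenyl on an amine nitrogen. For the measured compounds named here, no measured step covers this change directly. The numbers for compound 2 and compound 3 suggest that the shared core with a methoxy-free aryl on the amine nitrogen reaches the measurable range. The step from compound 1 to compound 4 is therefore expected to be an at least 7.5-fold lower number from compound 1 to compound 4 (0.87 log units; beyond the scatter), toward stronger inhibition. Compound 4 is estimated at 4000 nM, in the range 1500 nM to 15000 nM.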

Compound 4, half-maximal inhibitory concentration: > 30000 nM
Compound 4 gave a limit, no number; the forecaster's own chance of this, stated with the estimate: 30%; at least 7.5-fold (0.87 log units) between middle value and limit.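

Compound 1 and compound 4 both give limits in this assay, not numbers, and no step can be read between them. The compounds shown leave open whether 4-chlorophenyl and 3,4-dimethoxyphenyl on the amine nitrogen differ at all on this core.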